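Ester to Anilide: What Compound 3 Suggests for Compound 4

The source may report more compounds than this note shows. Statements on the series, on what has been measured and on what is new or still open speak of the compounds shown alone.

Compound 3 `CCOC(=O)c1sc(-c2nc3ccccc3n2Cc2ccccc2)nc1C` was examined in a functional assay on MCF7 cells (Homo sapiens) for cytotoxicity, read by MTT assay, with a stated time of 24 h; on this read-out lower numbers stand for stronger inhibition and higher numbers for weaker inhibition. In this assay compound 3 gives > 20000 nM, which is a limit of the assay and not a number. Compound 1 `CCOC(=O)c1sc(-c2nc3ccccc3n2CC)nc1C` gives > 20000 nM, again a limit. Compound 2 `CCOC(=O)c1sc(-c2nc3ccccc3n2C(C)C)nc1C` gives > 20000 nM, also a limit. All three values sit at the limit of > 20000 nM in this assay, at which 3 of the 3 values shown sit. The steps a step that the two limits leave unreadable from compound 1 to compound 2, a step that the two limits leave unreadable from compound 1 to compound 3 and a step that the two limits leave unreadable from compound 2 to compound 3 stay unreadable for that reason. Compound 4 `Cc1nc(-c2nc3ccccc3n2Cc2ccccc2)sc1C(=O)Nc1ccccc1` differs from compound 3 in that (anilino in place of ethoxy on a carbonyl carbon). Going by the values given here, none of the measured steps changes the carbonyl carbon, so no measured step bears directly on this change, and no direction can be read from the data. Compound 4 is thus expected to give about 20000 nM, with a range from 7000 nM to 60000 nM. That corresponds to an expected step of a number no higher from compound 3 to compound 4 (the limit leaves the size open).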

Compound 4, half-maximal inhibitory concentration: 3960 nM
Compound 4: middle estimate off by 5.1-fold (0.70 log units), on the high side, outside the stated range (below it).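

In this assay, the carbonyl carbon proves to be a place where a change can be read: anilino in place of ethoxy brings an at least 5.0-fold lower number from compound 3 to compound 4 (0.70 log units; beyond the scatter) on the shared core. Going by these compounds alone, the earlier steps, all on the aromatic nitrogen, could not be read, so this is the first readable change. Compound 4 alone carries a number rather than a limit: the limit of > 20000 nM in this assay, at which 3 of the 4 values shown sit.

The compounds shown leave open whether a methylamino group or a carboxylic acid on that carbonyl carbon would behave like anilino. They also leave open whether ethyl or isopropyl on the aromatic nitrogen would read differently from benzyl once the anilino group is present.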